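Swapping a nitrophenyl for a phenoxymethyl on the shared core

The source may report more compounds than this note shows. Statements on the series, on what has been measured and on what is new or still open speak of the compounds shown alone.

Measured so far:
- compound 1 `CCn1cc(-c2nnc(-c3ccc([N+](=O)[O-])cc3)o2)c(=O)c2cc(F)c(N3CCNCC3)cc21`: 74.3 ug/mL
- compound 2 `O=c1c(-c2nnc(-c3ccccc3)o2)cn(C2CC2)c2cc(N3CCNCC3)c(F)cc12`: 46 ug/mL

Both compounds were tested in a functional assay on A549 cells (Homo sapiens) for cytotoxicity, read by MTT assay; on this read-out higher numbers stand for weaker inhibition and lower numbers for stronger inhibition. Compound 1 has the higher of the two numbers, but the gap to compound 2 lies within the usual scatter, so the two cannot be told apart. Compound 3 `CCn1cc(-c2nnc(COc3ccccc3)o2)c(=O)c2cc(F)c(N3CCNCC3)cc21` has not been measured. It differs from compound 1 in one place: phenoxymethyl in place of 4-nitrophenyl on an aromatic carbon. For the measured compounds named here, no measured pair shows what this change does. For compound 3 the step of a 1.1-fold higher number from compound 1 to compound 3 (0.03 log units; within the scatter) is expected to stay within the scatter. The value of compound 3 is therefore estimated at 80 ug/mL, with a range from 35 ug/mL to 180 ug/mL.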

Compound 3, half-maximal inhibitory concentration: 76.8 ug/mL
For compound 3 the middle estimate is 1.0-fold (0.02 log units) above the measured one, within the range that was stated.
By their numbers in this assay, from the lowest: compounds 2, 1 and 3 (each within the scatter of the next).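

Phenoxymethyl in place of 4-nitrophenyl gives a 1.0-fold higher number from compound 1 to compound 3 (0.01 log units; within the scatter) in this assay, so at this position on the five-membered aromatic ring the two groups cannot be told apart. Both groups carry a six-membered aromatic ring of carbon only, and losing the nitro group while gaining the oxygen-linked methylene leaves no readable difference on this read-out. Nothing available explains this result. Open, going by these compounds, is whether a group without such a ring, such as an amine or a carboxylic acid, would also stay within the scatter at this position.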